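Amide swap on a series with high cytotoxicity numbers

A few compounds are considered here, and "the series" means these few. Any claim that something is new, unique, unknown or untested is made for them only; others in the source may bear on it.

Of the compounds shown here, three have been read in a functional assay on SK-BR-3 cells (Homo sapiens) for cytotoxicity, read by MTT assay, with a stated time of 72 h (a higher number here means a weaker inhibitor, a lower number a stronger inhibitor), so far. Compound 1 (`Nc1cccc(Nc2c(C(=O)NCc3ccc(F)cc3)nc(Br)c3cccnc23)c1`) gives > 10000 nM as a limit of the assay and not a number. Compound 2 (`CC(C)(C)OC(=O)N1CCN(c2c(C(=O)NCc3ccc(F)cc3)nc(Br)c3cccnc23)CC1`) gives 3000 nM as a true number. Compound 3 (`C[C@H](NC(=O)c1nc(Br)c2cccnc2c1N[C@H]1CC[C@H](N)CC1)c1ccc(F)cc1`) gives 9000 nM and so stands highest of the two true numbers, beyond the scatter from compound 2.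

Compound 4 (`N[C@H]1CC[C@H](Nc2c(C(=O)NC3CCCCC3)nc(Br)c3cccnc23)CC1`) differs from compound 3 in one place (cyclohexyl in place of 1-(4-fluorophenyl)ethyl on an amide-type nitrogen): cyclohexyl in place of 1-(4-fluorophenyl)ethyl on an amide-type nitrogen. Among the compounds with values here, no measured pair shows this change on its own. A small step towards a lower number is expected in this assay, no larger than the scatter, and its estimated size is a 1.3-fold lower number from compound 3 to compound 4 (0.11 log units; within the scatter) for this swap. The expectation starts from compound 3 at 9000 nM as the closest measured structure. A report at the limit remains possible for compound 4, given the limit of > 10000 nM in this assay, at which 1 of the 3 values shown sits, in the series. The estimate for compound 4 is 7000 nM with an expected range from 2500 nM to 18000 nM overall.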

Compound 4, half-maximal inhibitory concentration: 4200 nM
Compound 4: middle estimate off by 1.7-fold (0.22 log units), on the high side; measured number inside the range.
By their numbers in this assay, from the lowest: compounds 2 and 4 (each within the scatter of the next); then compound 3. At a limit, above all of these: compound 1.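

In this assay, within the data shown here, cyclohexyl in place of 1-(4-fluorophenyl)ethyl on an amide-type nitrogen gives a 2.1-fold lower number from compound 3 to compound 4 (0.33 log units; beyond the scatter), the first step that can be read at a single place. At this position, the aromatic ring, the fluorine and the defined stereocentre of the departing group can therefore all be lost without a rise in the number, although the step is only modest. Nothing in the data shown bears on the cause of this step.

This single pair changes the ring, the fluorine and the stereocentre together, so their separate contributions remain unresolved. Also open, going by these compounds, is how the number responds at this nitrogen to a longer alkyl chain or to a chain ending in a carboxylic acid.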